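This account rests on a few compounds, and the source may have more. Where it says the series, first, only, none or still open, it means among the compounds named here.

Of the compounds shown here, three sharing one core have been measured in a functional assay on A549 cells (Homo sapiens) for antiproliferative activity, read by sulforhodamine B assay, with a stated time of 72 h; a higher number here means a weaker inhibitor, a lower number a stronger inhibitor. Compound 1 (`COc1ccc(/C=C2\CCC=CC2=O)cc1`) gives 1460 nM, and compound 2 (`COc1ccc(/C=C2\CCC=CC2=O)cc1[N+](=O)[O-]`) gives 1480 nM. These two values lie within the scatter of each other, the step being a 1.0-fold higher number from compound 1 to compound 2 (0.01 log units; within the scatter). Compound 3 (`Cn1cc(/C=C2\CCC=CC2=O)c2ccccc21`) gives 4920 nM, the highest of the three numbers and clear of the scatter from both of the others, which makes it the weakest inhibitor of the set.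

Compound 4 (`CC(=O)n1cc(/C=C2\CCC=CC2=O)c2ccccc21`) differs from compound 3 in one group: acetyl in place of methyl on an aromatic nitrogen, (acetyl in place of methyl on an aromatic nitrogen). Going by the values given here, only one measured step bears on this, and only loosely, since it concerns nitro in place of hydrogen on an aromatic carbon: a 1.0-fold higher number from compound 1 to compound 2 (0.01 log units; within the scatter). Among the compounds with values here, no measured pair changes the group on that nitrogen, so the data give no direction for this change. With compound 3 at 4920 nM as the starting point, no step beyond the scatter is expected in this assay, although the margin is wide either way. The expected step is a 1.2-fold lower number from compound 3 to compound 4 (0.09 log units; within the scatter). The estimated value for compound 4 is 4000 nM, with an expected range from 1500 nM to 10000 nM.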

Compound 4, half-maximal inhibitory concentration: 4830 nM
Compound 4: the middle estimate sits 1.2-fold (0.08 log units) below what was measured; measured number inside the range.
By their numbers in this assay, from the lowest: compounds 1 and 2 (each within the scatter of the next); then compounds 4 and 3 (each within the scatter of the next).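

Going by these compounds alone, the first measured change on this aromatic nitrogen leaves the result in place: in this assay the switch from methyl to acetyl gives a 1.0-fold lower number from compound 3 to compound 4 (0.01 log units; within the scatter) and stays within the scatter. Within the data shown here, the earlier step concerned nitro in place of hydrogen on an aromatic carbon, so this is the first direct reading at the nitrogen, where a group of three heavy atoms with one hydrogen-bond acceptor and a group of one heavy atom with none cannot be told apart in this assay. No measurement shown here accounts for this lack of separation between compound 3 and compound 4.

These two groups alone do not show whether the nitrogen accepts any substituent without a shift in the number, and a plain hydrogen on the nitrogen, a longer chain such as butyl, a benzyl group or a chain ending in an amine or a carboxylic acid could still separate from them. On these data alone, it also remains open whether methyl and acetyl would stay this close on a different cell line or with a different exposure time.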